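Cyclohexyl to methyl on the ring amide nitrogen

The source may report more compounds than this note shows. Statements on the series, on what has been measured and on what is new or still open speak of the compounds shown alone.

Measured so far in an ADME assay on L6 cells (Rattus norvegicus) for cytotoxicity, read by microscopy and resazurin assay, with a stated time of 72 h; a lower number here means that less compound is needed, a higher number that more compound is needed for the effect:
Compound 1, `O=C1/C(=C/c2ccn(-c3ccccc3C(F)(F)F)c2)S/C(=N\c2ccccc2)N1C1CCCCC1`, gives only the limit > 180000 nM.
Compound 2, `O=C1/C(=C/c2cnn(-c3ccccc3C(F)(F)F)c2)S/C(=N\c2ccccc2)N1C1CCCCC1`, gives only the limit > 180000 nM.

Compound 2 therefore stands not at a number but at a bound of this assay, and it is not alone there: both values shown sit at the limit of > 180000 nM in this assay, at which 2 of the 2 values shown sit. For the measured compounds named here, no step between two measured compounds exists in this set, so no measured change in this assay can be read from it; the two limits show only that neither compound 1 nor compound 2 reached a half-maximal effect within the tested range.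

The unmeasured compound 3, `CN1C(=O)/C(=C/c2cnn(-c3ccccc3C(F)(F)F)c2)S/C1=N\c1ccccc1`, differs from compound 2 by methyl in place of cyclohexyl on an amide-type nitrogen in a ring. With nothing but limits to go on, the expected step in this assay is none beyond the usual scatter, that is, compound 3 is expected to sit at the same bound rather than to reveal a number. Compound 3 is accordingly estimated at 200000 nM, with a range from 90000 nM to 450000 nM. The step this estimate means, a step that the limit leaves unreadable from compound 2 to compound 3, is expected to be essentially flat.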

Compound 3, half-maximal effective concentration: 180000 nM
Compound 3: the middle estimate sits 1.1-fold (0.05 log units) above what was measured, within the range that was stated.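

In this assay, methyl in place of cyclohexyl on an amide-type nitrogen in a ring gives a number no higher from compound 2 to compound 3 (the limit leaves the size open), which shows that this position can carry the much smaller group without the read-out leaving the neighbourhood of the bound. Compound 2 has only a limit, > 180000 nM, so the size of this change cannot be read and no gain or loss can be assigned to it. Compound 3 is the only compound shown with a number rather than a limit, and that number has the same figure as the bound: the limit of > 180000 nM in this assay, at which 2 of the 3 values shown sit.

The compounds shown leave open whether another group at this position, such as an amine, a carboxylic acid or a longer chain, would bring the value clearly away from that figure. They also leave open whether methyl in place of cyclohexyl would act the same way on the core of compound 1, which carries cyclohexyl at this position and likewise gives only a limit.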